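Shortening the aryl ether on the pyridine of compound 3

The compounds below may be only part of what the source reports. "The series", "measured", "known", "first", "only" and "open" are said of these compounds alone.

Measured so far:
- compound 1 `CN1CC2C=C(c3cnccc3Cl)CC(C2)C1`: 1160 nM
- compound 2 `C1=C(c2cccnc2)C[C@H]2CNC[C@@H]1C2`: 0.2 nM
- compound 3 `Clc1ccc(Oc2cncc(C3=CC4CNCC(C3)C4)c2)cc1`: 1.9 nM

These three compounds share a bicyclic amine core carrying a pyridine ring, and all were tested in an in vitro assay on SH-EP1 cells for displacement of a labelled ligand from Neuronal acetylcholine receptor; alpha4/beta2 (Homo sapiens); a higher number here means a weaker inhibitor, a lower number a stronger inhibitor. Compound 3 gives 1.9 nM in this assay, the second highest of the three numbers. Compound 2, the closest to it, gives 0.2 nM, a distinctly lower number that lies beyond the usual scatter of the measurement. Compound 1, the furthest away, gives 1160 nM, a far higher number, again well beyond the scatter.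

Compound 4 `COc1cncc(C2=CC3CNCC(C2)C3)c1` has not yet been measured in this assay. It differs from compound 3 in one place:

methyl in place of 4-chlorophenyl on an oxygen on an aromatic ring

For the measured compounds named here, no pair of measured compounds shows exactly this kind of change, so the expectation rests on the spread of the three numbers above. Compound 2, which carries no substituent at all on its pyridine, sits well below compound 3, and compound 4 with its small methyl group on the oxygen is expected to land between those two. The step of a 3.8-fold lower number from compound 3 to compound 4 (0.58 log units; beyond the scatter) is therefore expected to be downward and modest. Compound 4 is estimated to give 0.5 nM in this assay, with a likely range from 0.1 nM to 3 nM.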

Compound 4, inhibition constant: 0.3 nM
Compound 4: middle estimate off by 1.7-fold (0.22 log units), on the high side, within the range that was stated.
By their numbers in this assay, from the lowest: compounds 2 and 4 (each within the scatter of the next); then compound 3; then compound 1.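

In this assay, for the compounds shown here, putting methyl in place of 4-chlorophenyl on the oxygen gives a 6.3-fold lower number from compound 3 to compound 4 (0.80 log units; beyond the scatter), the first change in this set that can be read at a single place. Here 7 heavy atoms, including an aromatic ring and a chlorine, give way to 1 heavy atom, yet compound 3 at 1.9 nM and compound 4 at 0.3 nM both have low numbers: this oxygen accepts a large group, but the 4-chlorophenyl is not needed for a low number, and removing it modestly improves the result. Nothing available here explains why the smaller group gives the lower number.

With only these two end points, the compounds shown leave open whether the number changes gradually with the size of the group on the oxygen, as an ethyl or a propyl chain would test, or whether it depends on the aromatic ring itself. They also leave open what the chlorine contributes, which a plain phenyl on the oxygen would address, and whether the oxygen can be replaced, for example by an amine.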